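Shrinking the alkyl group on the amino carbon

This account rests on a few compounds, and the source may have more. Where it says the series, first, only, none or still open, it means among the compounds named here.

Compound 1 `CCCCCCCOc1ccc(CCC(N)(CO)CCCC)cc1` in a functional assay on the whole organism (Popliteal lymph node) with Rattus norvegicus as the target; a lower number here means that less compound is needed, a higher number that more compound is needed for the effect: > 10 mg/kg, which is a limit of the assay and not a number.
Compound 2 `CCCCCCCOc1ccc(CCC(N)(CO)C(C)C)cc1` in this assay: 2.7 mg/kg.

Within the data shown here, compound 2 holds the only number given in this assay; the one further value shown is a limit. Among the measured compounds shown here, the step between them, an at least 3.7-fold lower number from compound 1 to compound 2 (0.56 log units; beyond the scatter), is the sole measured comparison in this set, and it runs from butyl to isopropyl at the carbon that also carries the amine and the hydroxymethyl.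

Compound 3 `CCCCCCCOc1ccc(CCC(N)(CC)CO)cc1` differs from compound 2 by hydrogen in place of methyl on a saturated chain carbon bound to two saturated chain carbons. For the measured compounds named here, this is a further trimming at the same carbon, in the same direction as the one measured step, which was an exchange of a longer alkyl for a shorter one. Going by the values given here, only that step bears on the question, and it was at least modest, so a further lowering of the number beyond the scatter is expected, though a single step rests on a limit of > 10 mg/kg in this assay, at which 1 of the 2 values shown sits, and leaves the size open.

Compound 3 is therefore expected to give about 1.3 mg/kg, within a range from 0.4 mg/kg to 4 mg/kg. The expected step is a 2.1-fold lower number from compound 2 to compound 3 (0.32 log units; beyond the scatter).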

Compound 3, dose for 50% inhibition: 0.059 mg/kg
Beside the measured number, compound 3's estimate is 22-fold (1.34 log units) above it; measured number below the stated range.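

At the carbon that carries the amine and the hydroxymethyl, small changes in the alkyl group can have a large effect: in this assay, going from isopropyl to ethyl removes a single methyl yet gives a large drop in the dose needed (a 46-fold lower number from compound 2 to compound 3 (1.66 log units; beyond the scatter)). Across the three compounds, the number falls as the group goes from butyl to isopropyl to ethyl, with no compound against that order, and the whole series spans a large range (an at least 160-fold lower number from compound 1 to compound 3 (2.22 log units; beyond the scatter)). That span is only a lower bound, since the value of compound 1 is a limit of the assay and not a number: (the limit of > 10 mg/kg in this assay, at which 1 of the 3 values shown sits).

From the compounds shown here alone, what the order means remains open, as the unbranched butyl and ethyl groups and the branched isopropyl group differ in both length and shape, and a propyl group at this carbon would help separate the two. A methyl group at the same carbon would show whether the number keeps falling as the group shrinks further or whether ethyl is already past the best size.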